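The source may report more compounds than this note shows. Statements on the series, on what has been measured and on what is new or still open speak of the compounds shown alone.

Of the compounds shown here, three built on one shared core have been tested in a functional assay on PC-3 cells (Homo sapiens) for antiproliferative activity, read by CCK-8 assay, with a stated time of 6 days; on this read-out higher numbers stand for weaker inhibition and lower numbers for stronger inhibition. Compound 1 `CCN(c1ccc(C#N)c(Cl)c1)c1cc(-c2cccs2)ccc1C` carries a thiophen-2-yl group. In this assay compound 1 gives > 30000 nM, which is a limit of the assay and not a number. Compound 2 `CCN(c1ccc(C#N)c(Cl)c1)c1cc(-c2ccoc2)ccc1C` carries a furan-3-yl group in its place. In this assay compound 2 gives > 30000 nM, again a limit rather than a number. Compound 3 `CCN(c1ccc(C#N)c(Cl)c1)c1cc(-c2cn[nH]c2)ccc1C` carries a 1H-pyrazol-4-yl group and is the only one of the three with an actual number: in this assay compound 3 gives 15300 nM. Two steps therefore point the same way, an at least 1.9-fold lower number from compound 1 to compound 3 (0.29 log units; that floor lies within the scatter) and an at least 1.9-fold lower number from compound 2 to compound 3 (0.29 log units; that floor lies within the scatter), whereas a step that the two limits leave unreadable from compound 1 to compound 2.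

Compound 4 `CCN(c1ccc(C#N)c(Cl)c1)c1cc(-c2ccco2)ccc1C` is the compound still to be measured. furan-2-yl in place of 1H-pyrazol-4-yl on an aromatic carbon The step from compound 2 to compound 3 bears on this change most closely, as furan-3-yl and furan-2-yl are close relatives, and that step was an at least 1.9-fold lower number from compound 2 to compound 3 (0.29 log units; that floor lies within the scatter). Walking back from 1H-pyrazol-4-yl to a furan ring is expected to undo that gain, so for compound 4 a weaker result is expected, with a fair chance that only a limit is reported. The estimate for compound 4 in this assay is 40000 nM, with a range from 18000 nM to 120000 nM. This amounts to an expected 2.6-fold higher number from compound 3 to compound 4 (0.42 log units; beyond the scatter).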

Compound 4, half-maximal inhibitory concentration: > 30000 nM
Compound 4: only a limit was reported; the forecaster's own chance of this, stated with the estimate: 65%; the middle value does not contradict the limit.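

At this position, on the aromatic carbon para to a methyl group, replacing 1H-pyrazol-4-yl with furan-2-yl exchanges a ring with 1 hydrogen-bond donor for one with 0 hydrogen-bond donors, and this assay records an at least 1.9-fold higher number from compound 3 to compound 4 (0.29 log units; that floor lies within the scatter). Furan now appears through two different ring positions, in compound 2 and compound 4, and neither yields a measured number, so 1H-pyrazol-4-yl in compound 3 remains the only group shown here with one. The steps among compound 1, compound 2 and compound 4 cannot be read, and these three compounds cannot be ranked against one another because each gives only a limit of the assay rather than a number: the limit of > 30000 nM in this assay, at which 3 of the 4 values shown sit.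

On these data alone, it remains open whether the hydrogen-bond donor of 1H-pyrazol-4-yl is what sets compound 3 apart, as that ring also differs from furan-2-yl in its ring atoms, and how far the three limit compounds lie from compound 3 is also unknown. A 1-methylpyrazol-4-yl group on the same carbon would bear on the first question, while an amine or a carboxylic acid there would show how groups outside this set of five-membered rings behave.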